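Taking the Chloro Group off Compound 2

A few compounds are considered here, and "the series" means these few. Any claim that something is new, unique, unknown or untested is made for them only; others in the source may bear on it.

In a functional assay on A549 cells (Homo sapiens) for antiproliferative activity, read by MTT assay, with a stated time of 48 h (on this read-out lower numbers stand for stronger inhibition and higher numbers for weaker inhibition), compound 2 `O=C(/C=C/c1ccc(/C=C/C(=O)c2cccc(Cl)c2)o1)NO` gives 18900 nM. That lies within the usual scatter of compound 1 `O=C(/C=C/c1ccc(/C=C/C(=O)c2ccc3ccccc3c2)o1)NO`, which gives 29400 nM, so these two results cannot be told apart. Compound 3 `O=C(/C=C/c1ccc(/C=C/C(=O)c2ccccc2)o1)NO` has not been measured yet. It differs from compound 2 by a single change, (hydrogen in place of chloro on an aromatic carbon), with hydrogen in place of chloro on an aromatic carbon, so that 3-chlorophenyl becomes phenyl. Among the measured compounds shown here, no measured pair shows this change directly, so the forecast is cautious. For the measured compounds named here, the only guide is how close compound 2 at 18900 nM sits to compound 1 at 29400 nM. In this assay, the estimated change is small, a 1.2-fold higher number from compound 2 to compound 3 (0.07 log units; within the scatter), and no step beyond the scatter is expected. For compound 3, the expected value is 22000 nM, with an estimated range of 10000 nM to 48000 nM.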

Compound 3, half-maximal inhibitory concentration: 20200 nM
Compound 3: the middle estimate sits 1.1-fold (0.04 log units) above what was measured, within the range that was stated.
By their numbers in this assay, from the lowest: compounds 2, 3 and 1 (each within the scatter of the next).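

The change of chloro to hydrogen now has a direct reading: in this assay it comes to a 1.1-fold higher number from compound 2 to compound 3 (0.03 log units; within the scatter), a step too small to separate the two compounds. At this place on the six-membered aromatic ring, then, the chloro group of the 3-chlorophenyl compound makes no measurable difference, and the plain phenyl of compound 3 cannot be told apart from it. No measurement shown here accounts for this result.

An amine, a carboxylic acid or a methoxy group at the same place could still give a number beyond the scatter, and the compounds shown do not say whether any would. As far as these compounds go, this single pair also speaks only for this core, so it remains open whether the same change would read alike on another one.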